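Series notes: piperidinyl to methylpiperazinyl on the propyl chain

The compounds below may be only part of what the source reports. "The series", "measured", "known", "first", "only" and "open" are said of these compounds alone.

Going by the values given here, compound 2 `O=C1NC(=O)C(c2cn(CCCN3CCCCC3)c3ccccc23)=C1Nc1ccccc1` is the only compound of the pair with a number in an assay on isolated protein for inhibition of protein kinase C epsilon type (Homo sapiens); on this read-out lower numbers stand for stronger inhibition and higher numbers for weaker inhibition; in this assay compound 2 gives 3430 nM. Compound 1 `CN(C)CCn1cc(C2=C(Nc3ccccc3)C(=O)NC2=O)c2ccccc21` is reported only as a limit in this assay, and in this assay compound 1 gives > 10000 nM. Among the compounds with values here, the one measured step, an at least 2.9-fold lower number from compound 1 to compound 2 (0.46 log units; beyond the scatter), is read against (the limit of > 10000 nM in this assay, at which 1 of the 2 values shown sits), so its size is known only as a lower bound. Compound 3 `CN1CCN(CCCn2cc(C3=C(Nc4ccccc4)C(=O)NC3=O)c3ccccc32)CC1` differs from compound 2 by 4-methylpiperazin-1-yl in place of piperidin-1-yl on a saturated chain carbon, three bonds along the chain from an aromatic nitrogen. Within the data shown here, no measured step touches the ring in question; the step from compound 1 to compound 2 alters the chain length and the amine at once, and these data do not separate the two parts. The change from compound 2 to compound 3 keeps the chain and exchanges only the saturated ring at its end. Compound 3 is therefore expected to sit close to compound 2, with a step of a 1.0-fold higher number from compound 2 to compound 3 (0.01 log units; within the scatter) that is expected to stay within the scatter. For compound 3 the estimate in this assay is 3500 nM, with a range from 1000 nM to 12000 nM.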

Compound 3, half-maximal inhibitory concentration: > 10000 nM
Compound 3 was reported as a limit; the forecaster's own chance of this, stated with the estimate: 25%; middle value at least 2.8-fold (0.45 log units) away from the limit.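

With the 3-(piperidin-1-yl)propyl chain kept and only its end ring exchanged for 4-methylpiperazin-1-yl, this assay gives an at least 2.9-fold higher number from compound 2 to compound 3 (0.46 log units; beyond the scatter), so the identity of the saturated ring at this chain end matters, which the earlier step, with chain and amine changing at once, could not show. Going by these compounds alone, compound 3 gives > 10000 nM, which is a limit and not a number, so the size of this step is known only as a lower bound: the limit of > 10000 nM in this assay, at which 2 of the 3 values shown sit. Compound 2 therefore remains the only compound with a number in this assay, and the step between the two compounds reported as limits cannot be read.

As far as these compounds go, it remains open whether the weaker result follows from the second ring nitrogen or from its methyl group, a question that piperazin-1-yl or morpholin-4-yl on the same propyl chain could help settle. From the compounds shown here alone, the separate contributions of chain length and amine also remain open, and a 2-(piperidin-1-yl)ethyl chain on the shared core would address them.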